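A few compounds are considered here, and "the series" means these few. Any claim that something is new, unique, unknown or untested is made for them only; others in the source may bear on it.

Measured so far in a functional assay on HeLa cells (Homo sapiens) for antiproliferative activity, read by MTT assay, with a stated time of 72 h; a lower number here means a stronger inhibitor, a higher number a weaker inhibitor:

Compound 1 `O=C1COc2ccc(-c3cnc(Cl)c(NS(=O)(=O)c4ccc(F)cc4)c3)cc2N1c1ccc(Cl)cc1`: > 40000 nM
Compound 2 `O=C1COc2ccc(-c3cnc(Cl)c(NS(=O)(=O)c4ccc(F)cc4)c3)cc2N1c1ccccc1`: 10300 nM
Compound 3 `O=C1COc2ccc(-c3cnc4ccccc4c3)cc2N1c1ccc(Cl)cc1`: > 40000 nM

The value for compound 1 is a limit of this assay, not a number. The value for compound 3 is likewise a limit. Only compound 2 gives a number in this assay, 10300 nM.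

Compound 1 and compound 2 share one core and differ in a single place: hydrogen in place of chloro on an aromatic carbon. This change gives an at least 3.8-fold lower number from compound 1 to compound 2 (0.58 log units; beyond the scatter). The size of that step is known only as a lower bound because of the limit of > 40000 nM in this assay, at which 2 of the 3 values shown sit.

Compound 3 carries a different core from compound 1; how the two cores differ is not broken down here. Compound 4 `O=C1COc2ccc(-c3cnc4ccccc4c3)cc2N1c1ccccc1` has not yet been measured in this assay. It stands to compound 3 as compound 2 stands to compound 1: hydrogen in place of chloro on an aromatic carbon. The place of the change is described in the same words in both pairs, so it is the same change made on a second core.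

With compound 3 sitting at the limit, as compound 1 did, the estimate for compound 4 rests on one measured step only. Among the measured compounds shown here, the step from compound 3 to compound 4 is expected to be about an at least 2.0-fold lower number from compound 3 to compound 4 (0.30 log units; that floor lies within the scatter), taking the change on compound 1 to compound 2, an at least 3.8-fold lower number from compound 1 to compound 2 (0.58 log units; beyond the scatter), as the only guide. Compound 4 is therefore estimated at 20000 nM, with a range from 5000 nM to 60000 nM, and a real chance that this assay again reports only a limit.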

Compound 4, half-maximal inhibitory concentration: > 40000 nM
Compound 4: only a limit was reported; the forecaster's own chance of this, stated with the estimate: 50%; middle value at least 2.0-fold (0.30 log units) from the limit.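

In this assay compound 4 gives > 40000 nM, which is a limit and not a number. The step from compound 3 to compound 4 cannot be read because both compounds sit at that limit: the limit of > 40000 nM in this assay, at which 3 of the 4 values shown sit.

The compounds shown leave open whether going from 4-chlorophenyl to phenyl lowers the number on the core of compound 3, as it does on the core of compound 1.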